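Moving the nitro group along a phenyl ring

This account rests on a few compounds, and the source may have more. Where it says the series, first, only, none or still open, it means among the compounds named here.

In a functional assay on SK-N-SH cells (Homo sapiens) for cytotoxicity, read by MTT assay, with a stated time of 24 h (on this read-out lower numbers stand for stronger inhibition and higher numbers for weaker inhibition), compound 1 (`C/C(=N\NC(=O)/C(C#N)=C/c1ccccc1)c1c(O)c2ccc(O)cc2oc1=O`) gives 13500 nM and compound 2 (`C/C(=N\NC(=O)/C(C#N)=C/c1ccc(O)cc1)c1c(O)c2ccc(O)cc2oc1=O`) gives 8120 nM. Compound 3 (`C/C(=N\NC(=O)/C(C#N)=C/c1cccc([N+](=O)[O-])c1)c1c(O)c2ccc(O)cc2oc1=O`) gives 28300 nM, the highest of the three numbers and so the weakest inhibition measured so far. Compound 4 (`C/C(=N\NC(=O)/C(C#N)=C/c1ccccc1[N+](=O)[O-])c1c(O)c2ccc(O)cc2oc1=O`) has the same atoms as compound 3, joined differently: 2-nitrophenyl in place of 3-nitrophenyl on a double-bonded chain carbon bound to a double-bonded chain carbon. Among the compounds with values here, no measured compound carries 2-nitrophenyl, so the data do not show directly what moving the nitro group does. Three measured steps give a sense of scale. Nitro in place of hydrogen gave a 2.1-fold higher number from compound 1 to compound 3 (0.32 log units; beyond the scatter), and hydroxy in place of hydrogen gave a 1.7-fold lower number from compound 1 to compound 2 (0.22 log units; within the scatter). The largest, a 3.5-fold higher number from compound 2 to compound 3 (0.54 log units; beyond the scatter), replaced 4-hydroxyphenyl with 3-nitrophenyl and is still modest. Since even that step is modest, only a small shift is expected in this assay, probably none beyond the scatter. That expectation amounts to a 1.3-fold lower number from compound 3 to compound 4 (0.11 log units; within the scatter). The estimate for compound 4 is 22000 nM, with an expected range of 9000 nM to 55000 nM.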

Compound 4, half-maximal inhibitory concentration: 12300 nM
For compound 4 the middle estimate is 1.8-fold (0.25 log units) above the measured one, within the range that was stated.
By their numbers in this assay, from the lowest: compounds 2, 4 and 1 (each within the scatter of the next); then compound 3.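

In this assay, where the nitro group sits on the phenyl ring matters at this double-bonded chain carbon: 2-nitrophenyl in place of 3-nitrophenyl gave a 2.3-fold lower number from compound 3 to compound 4 (0.36 log units; beyond the scatter) as a modest change. Adding a nitro group therefore need not shift the number, since nitro in place of hydrogen gave a 1.1-fold lower number from compound 1 to compound 4 (0.04 log units; within the scatter) with 2-nitrophenyl, and 2-nitrophenyl in place of 4-hydroxyphenyl gave a 1.5-fold higher number from compound 2 to compound 4 (0.18 log units; within the scatter) as well. Nothing available here explains why the two nitro placements differ.

The compounds shown leave open whether an amine or a carboxylic acid on the same phenyl ring would give numbers like those of the hydroxy and nitro compounds. They also leave open whether the difference between compound 3 and compound 4 would hold in other cell types.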